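Methyl for methoxy on the urea aryl of compound 2

This account rests on a few compounds, and the source may have more. Where it says the series, first, only, none or still open, it means among the compounds named here.

Compound 1 `COc1ccccc1NC(=O)NC1CC(C)(C)Oc2ccc(Cl)cc21`: in a functional assay (aorta) with Rattus norvegicus as the target (on this read-out lower numbers stand for an effect already at smaller amounts and higher numbers for an effect only at larger amounts of compound), compound 1 gives only the limit > 10000 nM.
Compound 2 `COc1ccc(NC(=O)NC2CC(C)(C)Oc3ccc(Cl)cc32)cc1`: in this assay compound 2 gives only the limit > 30000 nM.

Both measured compounds share one core and differ only in the aryl group on the urea nitrogen. Compound 2 stands at a limit, so its true potency is not known; compound 1 likewise sits at the limit of > 10000 nM in this assay, at which 1 of the 2 values shown sits, and compound 2 at the limit of > 30000 nM in this assay, at which 1 of the 2 values shown sits. Going by the values given here, the single measured step, a step that the two limits leave unreadable from compound 1 to compound 2, is therefore unreadable in size and direction.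

Compound 3 `Cc1cccc(NC(=O)NC2CC(C)(C)Oc3ccc(Cl)cc32)c1` carries the change (3-methylphenyl in place of 4-methoxyphenyl on an amide-type nitrogen). Among the compounds with values here, no measured step bears directly on a methyl for methoxy swap, and the one available step gives no readable size. Within the data shown here, the only guide is that both measured compounds are weak. Compound 3 is expected to fall around 20000 nM, within 4000 nM to 100000 nM, most likely reported again as a limit. That estimate means an expected step of an at least 1.5-fold lower number from compound 2 to compound 3 (0.17 log units; that floor lies within the scatter).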

Compound 3, half-maximal effective concentration: > 10000 nM
Compound 3: only a limit was reported; the forecaster's own chance of this, stated with the estimate: 70%; the middle value does not contradict the limit.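

In this assay, going by these compounds alone, compound 1, compound 2 and compound 3 all give only limits, and no step among them can be read in size or direction. The compounds shown leave open where each one's true potency lies and whether changing the urea aryl group alters it.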